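The source may report more compounds than this note shows. Statements on the series, on what has been measured and on what is new or still open speak of the compounds shown alone.

Measured compounds in a functional assay on MCF7 cells (Homo sapiens) for antiproliferative activity, read by sulforhodamine B assay, with a stated time of 48 h; a lower number here means a stronger inhibitor, a higher number a weaker inhibitor:
- compound 1 `CC(C)(C)C(=O)Nc1ccc(S(=O)(=O)Oc2ccccc2I)cc1`: 6600 nM
- compound 2 `CC(C)c1ccccc1OS(=O)(=O)c1ccc(NC(=O)CCCl)cc1`: 9000 nM

Compound 2 holds the highest of the two numbers in this assay, but its nearest neighbour, compound 1, sits within the scatter, so no order between the two can be read from these values. Among the compounds with values here, no step between measured compounds has been worked out, and the two differ in more than one place, so their pair gives only the two values shown.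

Compound 3 `O=C(CCCl)Nc1ccc(S(=O)(=O)Oc2ccccc2I)cc1` is the next compound to go into this assay. It departs from compound 2 in one place: iodo in place of isopropyl on an aromatic carbon. Within the data shown here, the iodo group that enters is the one already carried by compound 1, which in this assay gives 6600 nM, and the amide side of compound 3 is that of compound 2.

With both measured values lying close together, the step from compound 2 to compound 3 is expected to stay within the scatter, in no clear direction, giving a 1.3-fold lower number from compound 2 to compound 3 (0.11 log units; within the scatter). Compound 3 is accordingly estimated at 7000 nM in this assay, with a range from 3000 nM to 16000 nM.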

Compound 3, half-maximal inhibitory concentration: 8900 nM
The estimate for compound 3 lay 1.3-fold (0.10 log units) below the measured number; low and high end bracket the measured number.
By their numbers in this assay, from the lowest: compounds 1, 3 and 2 (each within the scatter of the next).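

In this assay, iodo in place of isopropyl on an aromatic carbon, ortho to a large group, gives a 1.0-fold lower number from compound 2 to compound 3 (0.00 log units; within the scatter). This place therefore tolerates either group with the 2-chloroethyl amide side held constant, and this pair gives the series its first reading of a change in one place. The other new pair reads the amide side with iodo held constant: 2-chloroethyl in place of tert-butyl on a carbonyl carbon gives a 1.3-fold higher number from compound 1 to compound 3 (0.13 log units; within the scatter), so neither single change separates the compounds in this assay, and nothing available explains this flat response.

Still open, going by these compounds, is whether an amine or a carboxylic acid on that aromatic carbon, or a longer chain on the carbonyl carbon, would move the number beyond the scatter. The compounds shown also leave open how isopropyl behaves alongside tert-butyl on the carbonyl carbon, so it cannot be said whether the two places act independently.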